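From 1-bromoethyl to hydroxymethyl: notes on compound 4

A few compounds are considered here, and "the series" means these few. Any claim that something is new, unique, unknown or untested is made for them only; others in the source may bear on it.

Values measured so far in a functional assay on HCT-116 cells (Homo sapiens) for inhibition, read by MTT assay, with a stated time of 48 h; a lower number here means a stronger inhibitor, a higher number a weaker inhibitor
compound 1 `COc1ccc(CN(C(=O)C(C)Br)c2cc(OC)c(OC)c(OC)c2)cc1O` gives 140 nM
compound 2 `COc1ccc(CNc2cc(OC)c(OC)c(OC)c2)cc1Cl` gives 41700 nM
compound 3 `C/C=C/C(=O)N(Cc1ccc(OC)c(OC)c1)c1cc(OC)c(OC)c(OC)c1` gives 32800 nM

Compound 1 has the lowest of the three numbers, and the gaps to compound 3, the nearest, and compound 2, the furthest, are both beyond the scatter. Compound 4 `COc1ccc(CN(C(=O)CO)c2cc(OC)c(OC)c(OC)c2)cc1O` has not yet been measured. It carries hydroxymethyl in place of 1-bromoethyl on a carbonyl carbon, a change counted as hydroxymethyl in place of 1-bromoethyl on a carbonyl carbon and made on the core of compound 1.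

For the measured compounds named here, no measured pair differs in one place, so the evidence for this step is indirect. Going by the values given here, compound 1 at 140 nM is the only measured compound with 1-bromoethyl, while compound 3 at 32800 nM and compound 2 at 41700 nM lack it but differ elsewhere too. A large step towards a weaker inhibitor, beyond the scatter, is therefore expected. The expected size is a 71-fold higher number from compound 1 to compound 4 (1.85 log units; beyond the scatter) in this estimate. For compound 4 the estimated value is 10000 nM with an expected range from 2000 nM to 40000 nM in this assay for now.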

Compound 4, half-maximal inhibitory concentration: 520 nM
Estimate against measurement, compound 4: 19-fold (1.28 log units) above; measured number outside the range, below it.
By their numbers in this assay, from the lowest: compound 1; then compound 4; then compounds 3 and 2 (each within the scatter of the next).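

In this assay, for the compounds shown here, putting hydroxymethyl in place of 1-bromoethyl on a carbonyl carbon gives a 3.7-fold higher number from compound 1 to compound 4 (0.57 log units; beyond the scatter), the first direct reading of this position. On the core of compound 1, the bromine-bearing group is therefore not needed for compound 4 to give 520 nM, and the modest step comes with a swap from 0 hydrogen-bond donors and 0 hydrogen-bond acceptors to 1 of each. No measured evidence accompanies the step to account for its size.

The compounds shown leave open how much of the step belongs to the bromine and how much to the rest of the 1-bromoethyl group. An ethyl or bromomethyl group on the same carbonyl carbon would separate the two, while aminomethyl or methoxymethyl would show how far the position accepts other heteroatom-bearing groups.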